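Moving the bromine and fluorine on the aniline ring

The compounds below may be only part of what the source reports. "The series", "measured", "known", "first", "only" and "open" are said of these compounds alone.

Measured so far in a functional assay on A549 cells (Homo sapiens) for antiproliferative activity, read by MTT assay, with a stated time of 72 h; a higher number here means a weaker inhibitor, a lower number a stronger inhibitor
- compound 1 `COc1cc2ncnc(Nc3ccc(F)c(Br)c3)c2cc1OCCCN1CCNCCNCCNCC1` gives 11800 nM as a number
- compound 2 `C#Cc1cccc(Nc2ncnc3cc(OC)c(OCCCN4CCNCCNCC4)cc23)c1` gives > 50000 nM as a limit
- compound 3 `COc1cc2ncnc(Nc3ccc(Br)cc3F)c2cc1OCCCN1CCNCCNCC1` gives 16100 nM as a number

Compound 3 stands at 16100 nM in this assay and lies within the scatter of compound 1 at 11800 nM on the same read-out. Compound 2 gives > 50000 nM in this assay and this is a limit, not a number.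

Compound 4 `COc1cc2ncnc(Nc3ccc(F)c(Br)c3)c2cc1OCCCN1CCNCCNCC1` has not yet been measured. It differs from compound 3 by 3-bromo-4-fluorophenyl in place of 4-bromo-2-fluorophenyl on a nitrogen on an aromatic ring and thus has 3-bromo-4-fluorophenyl in place of 4-bromo-2-fluorophenyl on a nitrogen on an aromatic ring.

Among the measured compounds shown here, the one measured step at this place is an at least 3.1-fold lower number from compound 2 to compound 3 (0.49 log units; beyond the scatter) and it starts from a limit. It shows that this place can matter, but it involves 3-ethynylphenyl and gives no direct size for the present exchange. Compound 1 carries the entering 3-bromo-4-fluorophenyl and gives 11800 nM in this assay as the closest guide. No step beyond the scatter is therefore expected. The estimated change is a 1.2-fold lower number from compound 3 to compound 4 (0.06 log units; within the scatter) and is expected to stay within the scatter. The expected value for compound 4 is 14000 nM in this assay with 6000 nM to 35000 nM as the estimated range.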

Compound 4, half-maximal inhibitory concentration: 34300 nM
Estimate against measurement, compound 4: 2.5-fold (0.39 log units) below, within the range that was stated.
By their numbers in this assay, from the lowest: compounds 1 and 3 (each within the scatter of the next); then compound 4. At a limit, above all of these: compound 2.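

In this assay, 3-bromo-4-fluorophenyl in place of 4-bromo-2-fluorophenyl on a nitrogen on an aromatic ring gives a 2.1-fold higher number from compound 3 to compound 4 (0.33 log units; beyond the scatter), so the arrangement of these substituents matters, which the earlier exchange of a different group at this place could not show. With 3-bromo-4-fluorophenyl held constant, the nine-membered ring in place of the larger ring of compound 1 gives a 2.9-fold higher number from compound 1 to compound 4 (0.46 log units; beyond the scatter), so both places register in this assay when each is changed alone, although both steps are modest. Compound 2 is a limit and not a number: the limit of > 50000 nM in this assay, at which 1 of the 4 values shown sits. Starting from that limit, the comparison reads an at least 1.4-fold lower number from compound 2 to compound 4 (0.16 log units; that floor lies within the scatter), and it gives only a floor.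

No measurement shown here bears on why the substituent arrangement or the ring size shifts the number. Still open, as far as these compounds go, is whether 4-bromo-2-fluorophenyl paired with the larger ring of compound 1 would follow the same trend, and how a 3-chloro-4-fluorophenyl group on the aniline nitrogen or an open-chain dimethylamino group in place of the ring would compare with the bromine and fluorine pairs and ring sizes seen so far.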